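The source may report more compounds than this note shows. Statements on the series, on what has been measured and on what is new or still open speak of the compounds shown alone.

Compound 1 `O=C(c1ccc(O)cc1)c1cccc(Cn2ccnc2)c1` gives 13 nM in an assay on isolated protein for inhibition of Aromatase (Homo sapiens), read by fluorescence, with stated times of 10 min and 60 min; on this read-out higher numbers stand for weaker inhibition and lower numbers for stronger inhibition. Compound 2 `COc1ccc(C(=O)c2cccc(Cn3ccnc3)c2)cc1` gives 13 nM. Compound 3 `CCC#CCOc1ccc(C(=O)c2ccc(Cn3ccnc3)cc2)cc1` gives 1430 nM.

Compound 2 stands level with compound 1 at the digits shown, and together they are the lowest of the three numbers; compound 3 sits far higher, but it differs from compound 2 in more than one place, so its value alone is not a clean guide. For the measured compounds named here, the one clean step, no change at the digits printed from compound 1 to compound 2 (within the scatter), shows that adding a methyl on the ring oxygen costs nothing. Compound 4 `CCCOc1ccc(C(=O)c2cccc(Cn3ccnc3)c2)cc1` continues in the same direction: ethyl in place of hydrogen on a saturated chain carbon bound to an oxygen on an aromatic ring. With only a neutral step to go on and a distant, much weaker compound 3 as a caution, a modest rise is expected, a 3.1-fold higher number from compound 2 to compound 4 (0.49 log units; beyond the scatter). Compound 4 is therefore estimated at 40 nM, within 10 nM to 200 nM.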

Compound 4, half-maximal inhibitory concentration: 2 nM
Beside the measured number, compound 4's estimate is 20-fold (1.30 log units) above it; the measured number lies below the stated range.
By their numbers in this assay, from the lowest: compound 4; then compounds 1 and 2 (each within the scatter of the next); then compound 3.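

Propoxy in place of methoxy on the ring oxygen gives a 6.5-fold lower number from compound 2 to compound 4 (0.81 log units; beyond the scatter) in this assay, and propyl in place of the hydrogen on that oxygen gives a 6.5-fold lower number from compound 1 to compound 4 (0.81 log units; beyond the scatter). Methyl on that oxygen had changed nothing beyond the scatter, so this is the first sign that the group placed there can lower the number, and that a propyl chain is accepted at this position. No available evidence says why the number falls.

Going by these compounds, whether a butyl chain would lower the number further remains open. So does the outcome with an amine or a carboxylic acid at the end of the chain.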